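Series notes: ethyl for propanoyl on the amino-pyridazinone core

This account rests on a few compounds, and the source may have more. Where it says the series, first, only, none or still open, it means among the compounds named here.

Among the measured compounds shown here, the three measured members share one core and one side chain and differ only at one aromatic carbon. Compound 1 `CCC(=O)c1c(C)nn(CCCN2CCN(c3ccc(C)cc3)CC2)c(=O)c1N` carries a propanoyl group there; in a functional assay on the whole organism (Abdomen, strain Swiss) for inhibition, with Mus musculus as the target, with stated times of 30 min, 10 min and 5 min, at a dose of 10 mg/kg by the oral route (on this read-out higher numbers stand for a stronger effect at the one dose given and lower numbers for a weaker effect), compound 1 gives 9%. Compound 2 `C=Cc1c(CCCC)nn(CCCN2CCN(c3ccc(C)cc3)CC2)c(=O)c1N` gives 0%, and compound 3 `C/C=C/c1c(C)nn(CCCN2CCN(c3ccc(C)cc3)CC2)c(=O)c1N` gives 0%. Compound 1 thus holds the highest of the three numbers, yet the gap to compound 2 and the gap to compound 3 are both within the scatter, so the three compounds are not separated by this read-out.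

For the measured compounds named here, the only single-point step is a number 9 percentage points lower from compound 1 to compound 3 (within the scatter). Compound 4 `CCc1c(C)nn(CCCN2CCN(c3ccc(C)cc3)CC2)c(=O)c1N` is the next member; the change from compound 1 is ethyl in place of propanoyl on an aromatic carbon. Going by the values given here, this step has not been measured; the one measured step at the same position, a number 9 percentage points lower from compound 1 to compound 3 (within the scatter), stayed within the scatter, and every number so far sits near zero. For compound 4 no step beyond the scatter is therefore expected in this assay, and the estimate is 3% with a range from 0% to 13%. The expected step is a number 6 percentage points lower from compound 1 to compound 4 (within the scatter).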

Compound 4, a percentage reported as inhibition, in the whole organism at one dose (the size of the read-out at that dose, not a potency): 23%
Estimate against measurement, compound 4: 20 percentage points below; the measured number lies above the stated range.
By their numbers in this assay, from the lowest: compounds 2, 3 and 1 (each within the scatter of the next); then compound 4.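

In this assay this position proves able to move the read-out: ethyl in place of propanoyl gives a number 14 percentage points higher from compound 1 to compound 4 (beyond the scatter), and ethyl in place of prop-1-en-1-yl gives a number 23 percentage points higher from compound 3 to compound 4 (beyond the scatter). Loss of the carbonyl alone does not account for the rise, since compound 3 also lacks it yet stays within the scatter of compound 1; among the groups shown, only ethyl stands apart from the others at this place. The data offer no explanation for the rise at this position.

Open, going by these compounds, is how the response depends on chain length and saturation at this carbon: propyl would show whether the saturated three-carbon chain keeps the rise, and methyl whether a shorter group extends it. A polar group such as a primary amine or a carboxylic acid at this place also remains an open question.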